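Compound 1 to compound 4: methyl to ethyl

A few compounds are considered here, and "the series" means these few. Any claim that something is new, unique, unknown or untested is made for them only; others in the source may bear on it.

Of the compounds shown here, three have been measured in an assay on isolated protein for binding affinity to 5-hydroxytryptamine receptor 1B (Homo sapiens); a lower number here means a stronger inhibitor, a higher number a weaker inhibitor. Compound 1 `COc1cc2c(cc1N1C[C@@H](C)N(C)[C@@H](C)C1)N(C(=O)c1ccc(-c3cccc(C)n3)c3ccccc13)CC2` gives 3.16 nM, level at the digits printed with compound 3 `COc1cc2c(cc1N1C[C@@H](C)N[C@@H](C)C1)N(C(=O)c1ccc(-c3ccc(-c4noc(C)n4)cc3C)cc1)CC2`, which gives 3.16 nM; the two numbers sit within the scatter of each other, so neither is placed above the other. Compound 2 `COc1cc2c(cc1N1C[C@@H](C)N(C)[C@@H](C)C1)N(C(=O)c1cccc(Cl)c1)CC2` gives 20 nM, and its gap to compound 1 is beyond the scatter. Together compound 1 and compound 3 carry the lowest numbers of the three.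

Compound 4 `CCN1[C@H](C)CN(c2cc3c(cc2OC)CCN3C(=O)c2ccc(-c3cccc(C)n3)c3ccccc23)C[C@@H]1C` has not yet been measured in this assay. It differs from compound 1 in one place: methyl in place of hydrogen on a saturated chain carbon bound to an amine nitrogen in a ring. Cut one bond further out, the same difference reads methyl to ethyl, 3,4,5-trimethylpiperazin-1-yl to 4-ethyl-3,5-dimethylpiperazin-1-yl. Among the measured compounds shown here, no step between measured compounds of this kind is available, so the expectation rests on the size of the change alone: one carbon added on a saturated chain carbon bound to an amine nitrogen in a ring. A step of a 1.3-fold higher number from compound 1 to compound 4 (0.10 log units; within the scatter) is expected, that is, no movement beyond the scatter. Compound 4 is estimated at 4 nM, with a range from 1.5 nM to 12 nM.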

Compound 4, inhibition constant: 3.98 nM
The estimate for compound 4 lay 1.0-fold (0.00 log units) above the measured number; low and high end bracket the measured number.
By their numbers in this assay, from the lowest: compounds 1, 3 and 4 (each within the scatter of the next); then compound 2.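

In this assay, going from 3,4,5-trimethylpiperazin-1-yl to 4-ethyl-3,5-dimethylpiperazin-1-yl gives a 1.3-fold higher number from compound 1 to compound 4 (0.10 log units; within the scatter). Among the compounds shown here, this is the first comparison of compounds that differ in one place, and it shows that a methyl added on a saturated chain carbon bound to an amine nitrogen in a ring leaves the number without movement beyond the scatter. No measurement at hand bears on the reason for this.

For the compounds shown here, one added carbon is the only change read at this position, so it stays open whether a longer chain such as propyl, or a 2-hydroxyethyl or cyclopropylmethyl group, would hold the number there. From the compounds shown here alone, it is also open whether the same change, made on compound 2, would give a step of like size.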